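Removing a Methyl from a Sulfonamide Nitrogen

The source may report more compounds than this note shows. Statements on the series, on what has been measured and on what is new or still open speak of the compounds shown alone.

Three compounds have so far been measured in a functional assay on the whole organism with Mus musculus as the target, with a stated time of 20 min; on this read-out higher numbers stand for an effect only at larger amounts of compound and lower numbers for an effect already at smaller amounts:

Compound 1 `CC(=O)NC1CCN(S(=O)(=O)c2ccc(F)cc2)CC1` gives 0.01 mg/kg.
Compound 2 `CC(C)S(=O)(=O)Nc1ccc(N(C)C(=O)c2ccccc2)cc1` gives 0.1 mg/kg.
Compound 3 `CC(C)S(=O)(=O)N(C)c1ccc(NC(=O)c2ccccc2)cc1` gives 0.01 mg/kg.

Compound 3 is level with compound 1 at the digits shown, and the two together stand at the lowest number of the three in this assay. Compound 2 stands at a higher number than compound 3, a gap beyond the usual scatter of this kind of measurement. Compounds 2 and 3 both carry one methyl on a nitrogen, but in different places, and nothing is known here about a compound carrying none; that is the gap the next compound fills.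

Compound 4 `CC(C)S(=O)(=O)Nc1ccc(NC(=O)c2ccccc2)cc1` has not yet been measured. It differs from compound 3 in one place: hydrogen in place of methyl on a sulfonamide nitrogen. Among the measured compounds shown here, no pair of measured compounds differs in just one place, so no measured step can be carried over to this change. Compound 3 and compound 2 show that moving a methyl between nitrogens can shift the number beyond the scatter, so some movement is possible, but the direction of removing it altogether is open. The expectation is a modest rise, a 3.0-fold higher number from compound 3 to compound 4 (0.48 log units; beyond the scatter), possibly no larger than the scatter itself. Compound 4 is therefore estimated at 0.03 mg/kg, with a range from 0.005 mg/kg to 0.2 mg/kg.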

Compound 4, minimum effective dose: 10 mg/kg
Compound 4: the middle estimate sits 330-fold (2.52 log units) below what was measured, and the stated range ends below it.
By their numbers in this assay, from the lowest: compounds 1 and 3 (each within the scatter of the next); then compound 2; then compound 4.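

In this assay, the hydrogen on each nitrogen of compound 4 turns out to matter a great deal: putting hydrogen in place of methyl on the sulfonamide nitrogen gives a large step (a 1000-fold higher number from compound 3 to compound 4 (3.00 log units; beyond the scatter)), so this methyl is far from a minor detail. The same exchange on the amide-type nitrogen also gives a large step (a 100-fold higher number from compound 2 to compound 4 (2.00 log units; beyond the scatter)), so among these three compounds, one methyl on either nitrogen goes with an effect at much smaller amounts than no methyl on either, and none of the three goes against this. Neither step comes with any further measurement that could explain it, so the data show how large the changes are but not the reason for them.

Going by these compounds, what remains open is whether a larger group, such as an ethyl or a longer chain, would serve on either nitrogen as well as a methyl does. Also open is what a methyl on both nitrogens at once would give, since each of these compounds carries at most one.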